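The compounds below may be only part of what the source reports. "The series", "measured", "known", "first", "only" and "open" are said of these compounds alone.

Going by the values given here, compound 2, whose structure is `O=C(O)C(=O)/C=C(\O)c1cccc(Br)c1`, is one of two compounds measured in an assay for inhibition of kynurenine 3-monooxygenase (Rattus norvegicus); on this read-out lower numbers stand for stronger inhibition and higher numbers for weaker inhibition. In this assay compound 2 gives 1700 nM. The other measured compound, compound 1 with structure `COC(=O)C(=O)/C=C(\O)c1cccc(F)c1`, gives 1600 nM in this assay. Among these two numbers compound 2 holds the higher one, but the gap to compound 1 lies within the scatter of the measurement, so the two readings cannot be told apart.

Compound 3, with structure `O=C(O)C(=O)/C=C(\O)c1cccc(F)c1`, is not yet measured. It differs from compound 2 in one place: fluoro in place of bromo on an aromatic carbon. Among the compounds with values here, no pair of measured compounds shows this halogen exchange on its own, so the effect of the change cannot be read from a completed step. What can be said is that compound 1, which already carries the fluoro group together with a methyl ester, sits at 1600 nM, close to compound 2. For compound 3 the expected step is therefore a 1.1-fold lower number from compound 2 to compound 3 (0.05 log units; within the scatter), a change not beyond the scatter. Compound 3 is estimated to reach 1500 nM, within a range from 600 nM to 4000 nM.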

Compound 3, half-maximal inhibitory concentration: 580 nM
The estimate for compound 3 lay 2.6-fold (0.41 log units) above the measured number; measured number outside the range, below it.
By their numbers in this assay, from the lowest: compound 3; then compounds 1 and 2 (each within the scatter of the next).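

In this assay, going by these compounds alone, the halogen on this aromatic carbon now has a completed step: fluoro in place of bromo gives a 2.9-fold lower number from compound 2 to compound 3 (0.47 log units; beyond the scatter), so the number at this place depends on which of these two halogens it carries, something no earlier pair could show. Within the data shown here, the acid end of the chain can also be read on its own for the first time, since hydrogen in place of methyl on an oxygen next to a carbonyl group gives a 2.8-fold lower number from compound 1 to compound 3 (0.44 log units; beyond the scatter). Both steps are modest but beyond the scatter, and both end at compound 3, which holds the lowest number of the three. No measurement shown accounts for either step.

The compounds shown hold only bromo and fluoro on the ring, so they leave open whether chloro, a methoxy group or plain hydrogen on that carbon would give a lower or a higher number than fluoro does. They also leave open whether an amide in place of the carboxylic acid would behave like the methyl ester of compound 1 or like the free acid of compound 3.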